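The source may hold more compounds than are shown below. What is called first, only, known or untested is meant among the compounds shown, and "the series" means these compounds.

Measured in an ADME assay on Raji cells (Homo sapiens) for cytotoxicity, read by luminescence, with a stated time of 72 h; on this read-out lower numbers stand for an effect already at smaller amounts and higher numbers for an effect only at larger amounts of compound:

Compound 1 `C=Cc1cccc(-c2[nH]c3cc(OC)ccc3c(=O)c2C(=O)OCC)c1`: > 21500 nM
Compound 2 `CCCCOc1cccc(-c2[nH]c3cc(OC)ccc3c(=O)c2C(=O)OCC)c1`: > 21500 nM
Compound 3 `CCOC(=O)c1c(-c2cccc(OC(F)(F)F)c2)[nH]c2cc(OC)ccc2c1=O`: > 21500 nM

Each of these three entries is a limit and not a number. Compound 3 therefore has no exact place in the series and shares its position with the other two: the limit of > 21500 nM in this assay, at which 3 of the 3 values shown sit.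

Compound 4 `CCOC(=O)c1c(-c2cccc(C(F)(F)F)c2)[nH]c2cc(OC)ccc2c1=O` has trifluoromethyl in place of trifluoromethoxy on an aromatic carbon, meta to a large group: trifluoromethyl in place of trifluoromethoxy on an aromatic carbon.

Within the data shown here, three measured steps bear on this change: a step that the two limits leave unreadable from compound 1 to compound 2, a step that the two limits leave unreadable from compound 1 to compound 3 and a step that the two limits leave unreadable from compound 2 to compound 3. None has a readable size, so none gives a measured effect for a swap of this group. In this assay, no step beyond the usual scatter is expected in either direction.

This expectation rests on compound 3, whose value of > 21500 nM is a limit. The expected step is a number no higher from compound 3 to compound 4 (the limit leaves the size open). For compound 4 the estimated value is 21500 nM, with an expected range of 10000 nM to 40000 nM.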

Compound 4, half-maximal effective concentration: > 21500 nM
Compound 4: no number, only a limit (the forecaster's own chance of this, stated with the estimate: 85%); the middle value lies on the limit itself.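

In this assay compound 4 gives > 21500 nM as a limit and not a number. Among these compounds, no step from compound 1, compound 2 or compound 3 to compound 4 can be read. The compounds shown leave open whether vinyl, butoxy, trifluoromethoxy and trifluoromethyl differ at all in this read-out: the limit of > 21500 nM in this assay, at which 4 of the 4 values shown sit.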